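From compound 3 to compound 4: one added methyl

The source may report more compounds than this note shows. Statements on the series, on what has been measured and on what is new or still open speak of the compounds shown alone.

compound 1 `Cc1ccc(-n2cc(COC(=O)c3c(C)nc4ccccc4c3-c3ccccc3)nn2)cc1`: 39000 nM
compound 2 `CCc1ccc(-n2cc(COC(=O)c3c(C)nc4ccccc4c3-c3ccccc3)nn2)cc1`: "not determined" (no result reported)
compound 3 `Cc1ccc(-n2cc(COC(=O)c3c(C)nc4ccc(Cl)cc4c3-c3ccccc3)nn2)cc1`: "not determined" (no result reported)

These three compounds were taken into an ADME assay on J774.A1 cells (Mus musculus) for cytotoxicity, read by MTT assay, with a stated time of 48 h (a higher number here means that more compound is tolerated, a lower number that less compound is tolerated), but only one of them yielded a number. Compound 3 therefore has no place on the scale. Its entry reads "not determined" (no result reported), and compound 2 likewise stands at "not determined" (no result reported). That leaves compound 1, at 39000 nM, as the sole numerical reference in the series.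

Next in line for measurement is compound 4 `CCc1ccc(-n2cc(COC(=O)c3c(C)nc4ccc(Cl)cc4c3-c3ccccc3)nn2)cc1`. The structural step is methyl in place of hydrogen on a saturated chain carbon bound to an aromatic carbon, so that 4-methylphenyl becomes 4-ethylphenyl. Within the data shown here, no measured pair shows what a change of this kind does, and compound 3 offers no starting number. The expectation therefore rests on the small size of the change, and no step beyond the scatter is expected in this assay, in either direction. With compound 1 at 39000 nM as the only anchor, the uncertainty remains wide, and compound 4 may also fail to give a number. For compound 4 the half-maximal cytotoxic concentration is estimated at 39000 nM, with an expected range of 13000 nM to 110000 nM.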

Compound 4, half-maximal cytotoxic concentration: 99000 nM
Beside the measured number, compound 4's estimate is 2.5-fold (0.40 log units) below it; low and high end bracket the measured number.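

In this assay, among these compounds, compound 4 gives 99000 nM while compound 3 carries no single number, so no step between compound 3 and compound 4 can be read. The compounds shown leave open whether going from 4-methylphenyl to 4-ethylphenyl changes how much compound the cells tolerate. Nothing further is at hand that bears on this result.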